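This account rests on a few compounds, and the source may have more. Where it says the series, first, only, none or still open, it means among the compounds named here.

Measured compounds in the series:

Compound 1, `CC(=O)N1N=C(c2cc(O)c(O)c([N+](=O)[O-])c2)CC1c1nccs1`, gives 84600 nM in an assay on isolated protein for inhibition of Amine oxidase [flavin-containing] A (Homo sapiens), read by fluorescence; a lower number here means a stronger inhibitor, a higher number a weaker inhibitor.
Compound 2, `CC(=O)N1N=C(c2cc(O)c(O)c([N+](=O)[O-])c2)CC1c1ccc(C#N)cc1`, gives 76600 nM in this assay.

Compound 2 holds the lowest of the two numbers recorded so far, but its step to compound 1 is small: a 1.1-fold lower number from compound 1 to compound 2 (0.04 log units; within the scatter). Both compounds share the same core and differ only in the group on the saturated ring carbon; the exchange of a five-membered heteroaryl for a six-membered aryl bearing a nitrile left the number essentially where it was.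

Compound 3, `CC(=O)N1N=C(c2cc(O)c(O)c([N+](=O)[O-])c2)CC1c1ccoc1`, is not yet measured. The change from compound 2 is furan-3-yl in place of 4-cyanophenyl on a saturated ring carbon. Going by the values given here, the only step in hand that bears on this position is the one from compound 1 to compound 2, and that step stayed within the scatter. With a five-membered heteroaryl returning at the same place, no step beyond the scatter is expected in this assay, in either direction.

For compound 3 the number in this assay is estimated at 80000 nM, in a range from 40000 nM to 170000 nM. The step that this estimate implies, a 1.0-fold higher number from compound 2 to compound 3 (0.02 log units; within the scatter), is expected to lie within the usual scatter.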

Compound 3, half-maximal inhibitory concentration: 90900 nM
Beside the measured number, compound 3's estimate is 1.1-fold (0.06 log units) below it; measured number inside the range.
By their numbers in this assay, from the lowest: compounds 2, 1 and 3 (each within the scatter of the next).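

With furan-3-yl on the saturated ring carbon, this assay gives a 1.2-fold higher number from compound 2 to compound 3 (0.07 log units; within the scatter), and the comparison with the thiazole gives a 1.1-fold higher number from compound 1 to compound 3 (0.03 log units; within the scatter). The position has now taken a six-membered aryl bearing a nitrile and two different five-membered heteroaryls, one with a ring oxygen and one with a ring sulfur and nitrogen, and all three compounds remain within the scatter of one another, so neither the ring size nor the nitrile separates them in these data. Nothing at hand gives a reason for this flat result.

As far as these compounds go, all three compounds carry an aromatic ring at this carbon, so it remains open whether an amine, a carboxylic acid or a plain alkyl chain there would move the number beyond the scatter. The rest of the shared core is the same throughout, so these compounds also leave open whether a change elsewhere, such as replacing the nitro group or the acetyl group, would shift the number more than any exchange at this position has.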